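Capping the Amino Group of Compound 2

The source may hold more compounds than are shown below. What is called first, only, known or untested is meant among the compounds shown, and "the series" means these compounds.

For the measured compounds named here, in a functional assay on KB cells (nasopharynx, Homo sapiens) for antiproliferative activity (on this read-out lower numbers stand for stronger inhibition and higher numbers for weaker inhibition), compound 2 (`N#Cc1c[nH]c2c(NS(=O)(=O)c3ccc(N)cc3)cccc12`) gives 4.4 ug/mL, the lower of the two numbers measured so far, and compound 1 (`N#Cc1c[nH]c2c(NS(=O)(=O)c3ccc(C(N)=O)cc3)cccc12`) gives 15 ug/mL. Compound 3 (`CS(=O)(=O)Nc1ccc(S(=O)(=O)Nc2cccc3c(C#N)c[nH]c23)cc1`) carries methylsulfonyl in place of hydrogen on a nitrogen on an aromatic ring, turning amino into methanesulfonamido: methylsulfonyl in place of hydrogen on a nitrogen on an aromatic ring. Going by the values given here, only one measured step involves that amino group, a 3.4-fold lower number from compound 1 to compound 2 (0.53 log units; beyond the scatter), a modest change in which amino replaced carbamoyl. With so little evidence, a similarly modest move back toward higher numbers is expected in this assay, an estimated 1.6-fold higher number from compound 2 to compound 3 (0.20 log units; within the scatter). The estimate for compound 3 is 7 ug/mL, with an expected range of 2 ug/mL to 25 ug/mL.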

Compound 3, half-maximal inhibitory concentration: 15 ug/mL
Compound 3: the middle estimate sits 2.1-fold (0.33 log units) below what was measured, and the stated range covers the measured number.
By their numbers in this assay, from the lowest: compound 2; then compounds 1 and 3 (each within the scatter of the next).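

Methylsulfonyl on the nitrogen of compound 2 gives a 3.4-fold higher number from compound 2 to compound 3 (0.53 log units; beyond the scatter) in this assay, so capping this amino group weakens inhibition rather than leaving it unchanged. Comparing the two capped or carbamoyl-bearing compounds shows no change at the digits printed from compound 1 to compound 3 (within the scatter) on this read-out, which leaves the free amino group of compound 2 alone at the lower number. No measurement here explains the loss.

On these data alone, whether a smaller cap such as acetyl or a single methyl on the nitrogen keeps the lower number remains open. So does the effect of a longer chain on the sulfonyl group.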